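The source may hold more compounds than are shown below. What is called first, only, known or untested is meant among the compounds shown, and "the series" means these compounds.

Within the data shown here, in a functional assay on MDA-MB-231 cells (Homo sapiens) for antiproliferative activity, read by sulforhodamine B assay, with a stated time of 48 h (on this read-out lower numbers stand for stronger inhibition of growth and higher numbers for weaker inhibition of growth), only two numbers are known so far. Among the measured compounds shown here, compound 1 `Cc1cc2c(cc1C)C(Cl)=C(c1nnc(-c3cccc(Cl)c3)o1)CCC2` gives 3310 nM, and compound 2 `Cc1cc2c(cc1C)C(Cl)=C(c1nnc(-c3cccc(I)c3)o1)CCC2` gives 2670 nM, so compound 2 stands level with its only neighbour once the usual scatter is allowed for. Compound 3 `Cc1cc2c(cc1C)C(Cl)=C(c1nnc(-c3cccc(C(F)(F)F)c3)o1)CCC2` keeps the shared core and alters one group: trifluoromethyl in place of iodo on an aromatic carbon. This puts trifluoromethyl in place of iodo on an aromatic carbon. For the measured compounds named here, only one measured step bears on this change, an exchange of chloro for iodo at the same place, and it shows a 1.2-fold lower number from compound 1 to compound 2 (0.09 log units; within the scatter). That step stays within the scatter, but trifluoromethyl is not a halogen, so the guide is loose. No clear shift in either direction is expected. The estimated change is a 1.0-fold higher number from compound 2 to compound 3 (0.02 log units; within the scatter). Compound 3 is expected near 2800 nM, with an estimated range from 1200 nM to 6000 nM.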

Compound 3, concentration for 50% growth inhibition: 2460 nM
Estimate against measurement, compound 3: 1.1-fold (0.06 log units) above, and the stated range covers the measured number.
By their numbers in this assay, from the lowest: compounds 3, 2 and 1 (each within the scatter of the next).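

In this assay, trifluoromethyl in place of iodo gives a 1.1-fold lower number from compound 2 to compound 3 (0.04 log units; within the scatter), and trifluoromethyl in place of chloro gives a 1.3-fold lower number from compound 1 to compound 3 (0.13 log units; within the scatter). The earlier pair compared only two halogens, whereas these steps show that a group of four heavy atoms, and not a halogen, also leaves the number within the scatter at this place on the aromatic ring, so chloro, iodo and trifluoromethyl cannot be told apart here. No measurement shown explains this lack of separation.

From the compounds shown here alone, all three groups carry no hydrogen-bond donors or acceptors, so it remains open whether an amine, a hydroxyl or a carboxylic acid at this place would shift the number beyond the scatter. Also open, going by these compounds, is whether removing the group altogether, leaving only hydrogen on that carbon, would change growth inhibition.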